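From Carboxy to 2-Carboxyethenyl on the Shared Core

A few compounds are considered here, and "the series" means these few. Any claim that something is new, unique, unknown or untested is made for them only; others in the source may bear on it.

Compound 1, `CC1CCC(=NNc2ccccc2)c2ncc(C(=O)O)c(=O)n21`, gives 0.6 umol/kg in a functional assay on the whole organism with Rattus norvegicus as the target; a lower number here means that less compound is needed, a higher number that more compound is needed for the effect.
Compound 2, `C[C@H]1CC/C(=N\Nc2ccccc2)c2ncc(C(=O)O)c(=O)n21`, gives 0.3 umol/kg in this assay.
Compound 3, `C[C@@H]1CC/C(=N\Nc2ccccc2)c2ncc(C(=O)O)c(=O)n21`, gives 54.8 umol/kg in this assay.

Compound 2 has the lowest of the three numbers. Its nearest neighbour is compound 1: a 2.0-fold lower number from compound 1 to compound 2 (0.30 log units; within the scatter) stays within the scatter and rests only on drawn configuration, as the fact that one of compounds 1 and 2 is drawn with a defined configuration and the other without, at the place where they differ shows. Compound 3 stands far away: a 180-fold higher number from compound 2 to compound 3 (2.26 log units; beyond the scatter), a difference that traces back to the ring stereocentre alone because of the fact that compounds 2 and 3 differ only in the configuration as drawn. Compound 1 to compound 3 shows the same picture, a 91-fold higher number from compound 1 to compound 3 (1.96 log units; beyond the scatter), with the fact that one of compounds 1 and 3 is drawn with a defined configuration and the other without, at the place where they differ as the only difference between them.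

Compound 4, `C[C@H]1CC/C(=N\Nc2ccccc2)c2ncc(/C=C/C(=O)O)c(=O)n21`, keeps the configuration of compound 2 and changes the acid instead: 2-carboxyethenyl in place of carboxy on an aromatic carbon. Among the measured compounds shown here, none of the measured steps touches this position; all three concern configuration only, so they give no direct guide to the size or direction of this change. The estimate therefore leans on compound 2 itself, with a wide range to cover the untested homologation. Compound 4 is expected to give 1 umol/kg in this assay, between 0.2 umol/kg and 6 umol/kg, which means an expected 3.3-fold higher number from compound 2 to compound 4 (0.52 log units; beyond the scatter).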

Compound 4, dose for 50% inhibition: 0.15 umol/kg
For compound 4 the middle estimate is 6.7-fold (0.82 log units) above the measured one, and the stated range ends above it.
By their numbers in this assay, from the lowest: compounds 4, 2 and 1 (each within the scatter of the next, the first and the last beyond it); then compound 3.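

Among the compounds shown here, replacing carboxy with 2-carboxyethenyl on this aromatic carbon, in the configuration of compound 2, gives (a 2.0-fold lower number from compound 2 to compound 4 (0.30 log units; within the scatter)), so the first measured change at this position leaves the number in this assay unresolved from that of compound 2. For the compounds shown here, the chain can therefore grow from 3 to 5 heavy atoms and gain a double bond outside aromatic rings, with the acid kept at its end, without a step beyond the scatter, whereas the earlier compounds showed large steps only at the ring stereocentre and said nothing about this place. The recorded reasons concern only drawn configuration, so nothing given here explains why this replacement leaves the number within the scatter.

Going by these compounds, it remains open whether an amide, a methyl ester or a saturated chain ending in a carboxylic acid would stay as close to compound 2 at this position in the same assay. It is also open whether the large gap seen at the ring stereocentre persists when 2-carboxyethenyl is present, since the opposite configuration is shown here only with carboxy.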